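A few compounds are considered here, and "the series" means these few. Any claim that something is new, unique, unknown or untested is made for them only; others in the source may bear on it.

Three compounds sharing one core, and differing in a single group on an aromatic carbon, have been measured in a functional assay on HepG2 cells (Homo sapiens) for inhibition, read by MTT assay, with a stated time of 72 h; on this read-out lower numbers stand for stronger inhibition and higher numbers for weaker inhibition. Compound 1 `O=C(Nc1ccccc1)C1CCN(C/C=C/c2ccccc2)CC1` carries only hydrogen at that place and gives 90900 nM. Compound 2 `COc1cccc(NC(=O)C2CCN(C/C=C/c3ccccc3)CC2)c1` carries a methoxy group and gives 78600 nM. Compound 3 `O=C(Nc1cccc(Br)c1)C1CCN(C/C=C/c2ccccc2)CC1` carries a bromo group and gives 19200 nM, the lowest of the three numbers.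

Compound 4 `O=C(Nc1ccc(F)c(Br)c1)C1CCN(C/C=C/c2ccccc2)CC1` goes one step further, from 3-bromophenyl to 3-bromo-4-fluorophenyl: fluoro in place of hydrogen on an aromatic carbon. This puts fluoro in place of hydrogen on an aromatic carbon, ortho to the bromo group and para to a large group.

Going by the values given here, no measured step adds a fluoro group, so the guidance is indirect. Methoxy in place of hydrogen gave a 1.2-fold lower number from compound 1 to compound 2 (0.06 log units; within the scatter). Bromo in place of hydrogen gave a 4.7-fold lower number from compound 1 to compound 3 (0.68 log units; beyond the scatter), and bromo in place of methoxy gave a 4.1-fold lower number from compound 2 to compound 3 (0.61 log units; beyond the scatter). Single swaps on this aromatic carbon have therefore ranged from no visible change to a modest drop, and a small downward move is the cautious expectation in this assay. The expected change is a 1.3-fold lower number from compound 3 to compound 4 (0.11 log units; within the scatter), which may well not stand out from the scatter. In this assay the estimate for compound 4 is 15000 nM, with an expected range from 6000 nM to 35000 nM.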

Compound 4, half-maximal inhibitory concentration: 8190 nM
Compound 4: middle estimate off by 1.8-fold (0.26 log units), on the high side; low and high end bracket the measured number.
By their numbers in this assay, from the lowest: compound 4; then compound 3; then compounds 2 and 1 (each within the scatter of the next).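

In this assay the fluoro group, a single heavy atom placed ortho to the bromo group, gives a 2.3-fold lower number from compound 3 to compound 4 (0.37 log units; beyond the scatter) and so moves the number by more than the scatter on a ring where bromo had already lowered it. The second change on the ring therefore brings a further drop instead of leaving the number where compound 3 had it, and the two changes together give an 11-fold lower number from compound 1 to compound 4 (1.05 log units; beyond the scatter) for 3-bromo-4-fluorophenyl in place of phenyl, a large step, and a 9.6-fold lower number from compound 2 to compound 4 (0.98 log units; beyond the scatter) for the same group in place of 3-methoxyphenyl. Nothing measured alongside these numbers offers an explanation for the drop.

The compounds shown leave open whether fluoro would lower the number on the plain phenyl ring without the bromo group, and whether a chloro group, a nitrile or an amine at the same place would act as fluoro does here. Going by these compounds, they also cover only changes on this one aromatic ring, so what a hydroxyl group or a longer chain elsewhere on the shared core would do remains unknown.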